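The source may hold more compounds than are shown below. What is called first, only, known or untested is meant among the compounds shown, and "the series" means these compounds.

Compound 1 `CC(=O)OCCC(=O)O[C@H](CC=C(C)C)C1=CC(=O)c2c(O)ccc(O)c2C1=O` is one of three compounds tested in a functional assay on DU-145 cells (Homo sapiens) for cytotoxicity, read by MTT assay (a higher number here means a weaker inhibitor, a lower number a stronger inhibitor), where compound 1 gives 15700 nM, the second highest of the three numbers. Compound 2 `CC[C@@](C)(O)CC(=O)O[C@H](CC=C(C)C)C1=CC(=O)c2c(O)ccc(O)c2C1=O` gives 12700 nM in this assay, and compound 3 `COCCO[C@H](CC=C(C)C)C1=CC(=O)c2c(O)ccc(O)c2C1=O` gives 43200 nM. The step of a 1.2-fold lower number from compound 1 to compound 2 (0.09 log units; within the scatter) stays within the scatter, whereas a 2.8-fold higher number from compound 1 to compound 3 (0.44 log units; beyond the scatter) goes beyond it.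

Compound 4 `CCCC(CC(=O)O[C@H](CC=C(C)C)C1=CC(=O)c2c(O)ccc(O)c2C1=O)OC(C)=O` differs from compound 1 by propyl in place of hydrogen on a saturated chain carbon bound to an oxygen next to a carbonyl group and a saturated chain carbon. Within the data shown here, the only step that bears on this change is the small one from compound 1 to compound 2, which alters the same ester chain and shows a 1.2-fold lower number from compound 1 to compound 2 (0.09 log units; within the scatter). Among the measured compounds shown here, no measured step adds a propyl at that carbon, so the expectation is a step of about a 1.1-fold lower number from compound 1 to compound 4 (0.05 log units; within the scatter), not beyond the scatter. Compound 4 is therefore expected to give 14000 nM, with a range of 6000 nM to 32000 nM.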

Compound 4, half-maximal inhibitory concentration: 55700 nM
For compound 4 the middle estimate is 4.0-fold (0.60 log units) below the measured one; measured number outside the range, above it.
By their numbers in this assay, from the lowest: compounds 2 and 1 (each within the scatter of the next); then compounds 3 and 4 (each within the scatter of the next).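

In this assay, propyl in place of hydrogen on this saturated chain carbon gives a 3.5-fold higher number from compound 1 to compound 4 (0.55 log units; beyond the scatter), so this ester chain does not tolerate every change, which the small step between the first two compounds could not show. The other step into this compound, a 4.4-fold higher number from compound 2 to compound 4 (0.64 log units; beyond the scatter), points the same way. No measurement shown here explains the rise.

On these data alone, whether methyl or ethyl at this carbon would already raise the number remains open. So does whether an amine or a carboxylic acid could be placed there.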